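A few compounds are considered here, and "the series" means these few. Any claim that something is new, unique, unknown or untested is made for them only; others in the source may bear on it.

Going by the values given here, compound 1 `O=C(O)CCn1c(=O)oc2cc(OCC3CCC3)c(Cl)cc21` is one of three compounds measured in an assay for inhibition of kynurenine 3-monooxygenase (Homo sapiens), read by mass spectrometry, with a stated time of 1 h; a higher number here means a weaker inhibitor, a lower number a stronger inhibitor. In this assay compound 1 gives 25.1 nM, the highest of the three numbers. Compound 2 `CC(C)Cc1cc2oc(=O)n(CCC(=O)O)c2cc1Cl` gives 12.6 nM, and the step of a 2.0-fold lower number from compound 1 to compound 2 (0.30 log units; within the scatter) is an isobutyl in place of cyclobutylmethoxy on an aromatic carbon. Compound 3 `Cc1ccc([C@@H](C)Oc2cc3onc(CCC(=O)O)c3cc2Cl)nn1`, which has a different core and a larger ether side chain, gives 2 nM, so the two values of compound 1 and compound 3 lie well apart.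

Compound 4 `COc1cc2oc(=O)n(CCC(=O)O)c2cc1Cl` differs from compound 1 by hydrogen in place of cyclobutyl on a saturated chain carbon bound to an oxygen on an aromatic ring, so cyclobutylmethoxy becomes methoxy. Among the compounds with values here, no measured step removes the cyclobutyl while keeping the ether; the one step that touches this side chain, a 2.0-fold lower number from compound 1 to compound 2 (0.30 log units; within the scatter), swaps it for a group of similar size and stays within the scatter. The numbers for compound 3 point to a larger side chain sitting at a lower number than compound 1. Compound 4 is therefore expected to give a higher number, with an expected step of a 6.0-fold higher number from compound 1 to compound 4 (0.78 log units; beyond the scatter). The estimate for compound 4 is 150 nM, with a range from 40 nM to 600 nM.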

Compound 4, half-maximal inhibitory concentration: 12.6 nM
For compound 4 the middle estimate is 12-fold (1.08 log units) above the measured one, outside the stated range (below it).
By their numbers in this assay, from the lowest: compound 3; then compounds 2, 4 and 1 (each within the scatter of the next).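

Taking the cyclobutyl off the ether, a 2.0-fold lower number from compound 1 to compound 4 (0.30 log units; within the scatter), stays within the scatter in this assay, so on this core the number seen for cyclobutylmethoxy does not depend on the cyclobutyl ring. The second step, no change at the digits printed from compound 2 to compound 4 (within the scatter), shows that methoxy and isobutyl cannot be told apart at this position, and together with a 2.0-fold lower number from compound 1 to compound 2 (0.30 log units; within the scatter) it shows that these three side chains, which differ in size and in whether an ether oxygen is present, all read alike here. Nothing measured alongside these values speaks to why the three read alike.

The compounds shown leave open whether a hydroxyl, an amine or a longer ether chain at this position would give a number outside the scatter of these three. They also leave open whether compound 3, at 2 nM, owes its value to its core or to its ether side chain; it differs from these compounds in more than one place.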